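This account rests on a few compounds, and the source may have more. Where it says the series, first, only, none or still open, it means among the compounds named here.

Of the compounds shown here, three built on one shared core have been measured in a functional assay on SUP-B15 cells (Homo sapiens) for antiproliferative activity, with a stated time of 72 h; a higher number here means that more compound is needed for the effect, a lower number that less compound is needed. Compound 1 `COc1ccc(-c2cc(=O)c3c(OC)cc(OC)cc3n2S(=O)(=O)c2ccc(C=O)cc2)cc1` reaches only a limit in this assay, given as > 34400 nM, and so carries no number. Compound 2 `COc1ccc(-c2cc(=O)c3c(OC)cc(OC)cc3n2S(=O)(=O)c2ccc([N+](=O)[O-])cc2)cc1` gives 17100 nM in this assay, and compound 3 `COc1ccc(-c2cc(=O)c3c(OC)cc(OC)cc3n2S(=O)(=O)c2c(F)c(F)c(F)c(F)c2F)cc1` gives 4100 nM. Of the two numbers, compound 3 holds the lowest, and compound 2 is its nearest neighbour, the step between them being a 4.2-fold lower number from compound 2 to compound 3 (0.62 log units; beyond the scatter). Starting instead from compound 1, the exchange of the ring on the sulfonyl sulfur gave an at least 8.3-fold lower number from compound 1 to compound 3 (0.92 log units; beyond the scatter).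

Compound 4 `COc1ccc(-c2cc(=O)c3c(OC)cc(OC)cc3n2S(=O)(=O)c2ccc(C)cc2)cc1` differs from compound 3 in one place: 4-methylphenyl in place of 2,3,4,5,6-pentafluorophenyl on a sulfonyl sulfur. Both measured steps that end at compound 3 altered the same ring on the sulfonyl sulfur, and both brought the number down, one by an at least 8.3-fold lower number from compound 1 to compound 3 (0.92 log units; beyond the scatter) and the other by a 4.2-fold lower number from compound 2 to compound 3 (0.62 log units; beyond the scatter). Compound 4 moves away from the pentafluorophenyl group, so a modest step back toward a higher number in this assay is expected, namely a 3.7-fold higher number from compound 3 to compound 4 (0.56 log units; beyond the scatter). Compound 4 is therefore estimated at 15000 nM, with a range from 5000 nM to 40000 nM.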

Compound 4, half-maximal effective concentration: > 44800 nM
Compound 4 gave a limit, no number; the forecaster's own chance of this, stated with the estimate: 25%; middle value at least 2.9-fold (0.47 log units) away from the limit.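

Compound 4 reaches only a limit in this assay, not a number: the limit of > 44800 nM in this assay, at which 1 of the 4 values shown sits.

Even so, putting 4-methylphenyl in place of 2,3,4,5,6-pentafluorophenyl on the sulfonyl sulfur gives an at least 10-fold higher number from compound 3 to compound 4 (1.03 log units; beyond the scatter), a large step and the first measured change at this position that leads away from compound 3 by so much. Methyl in place of nitro on the aromatic carbon gives an at least 2.6-fold higher number from compound 2 to compound 4 (0.41 log units; beyond the scatter), which shows that the choice of group on a single phenyl ring also counts at this position, and that the fully fluorinated ring is not the only feature separating these compounds.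

The step between compound 1 and compound 4 cannot be read, since each of the two compounds has only a limit, and the limit for compound 1 is this one: the limit of > 34400 nM in this assay, at which 1 of the 4 values shown sits.

Going by these compounds, it also remains open whether the fluorines must all be present, or whether a phenyl ring carrying a single fluorine, an amine or a carboxylic acid in the place of the methyl would bring the number down toward that of compound 3.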